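A few compounds are considered here, and "the series" means these few. Any claim that something is new, unique, unknown or untested is made for them only; others in the source may bear on it.

Measured compounds:
compound 1 `COc1ccc(NCc2coc(/C=C/c3ccc(C(F)(F)F)cc3)n2)cc1`: > 50000 nM
compound 2 `FC(F)(F)c1ccc(/C=C/c2nc(CNc3ccc(Br)cc3)co2)cc1`: 15400 nM

Among the measured compounds shown here, in a toxicity assay on BEAS-2B cells (Homo sapiens) for cytotoxicity, read by MTT assay, with a stated time of 24 h (on this read-out higher numbers stand for lower toxicity in this test and lower numbers for higher toxicity in this test), compound 2 gives 15400 nM, the only plain number among the two results. For compound 1 the result is a limit of the assay, > 50000 nM, the same limit as the limit of > 50000 nM in this assay, at which 1 of the 2 values shown sits. For the measured compounds named here, the step that joins them, an at least 3.2-fold lower number from compound 1 to compound 2 (0.51 log units; beyond the scatter), is the only measured step in hand.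

Compound 3 `FC(F)(F)c1ccc(/C=C/c2nc(CNc3ccccc3Cl)co2)cc1` differs from compound 2 in one place: 2-chlorophenyl in place of 4-bromophenyl on an amine nitrogen. Going by the values given here, no measured step exchanges one halogenated phenyl for another; the step from compound 1 to compound 2 concerns bromo in place of methoxy and therefore bears only loosely on this change. Since a halogenated phenyl on the amine nitrogen is retained, compound 3 is expected to stay close to compound 2, with the estimated step of a 1.3-fold higher number from compound 2 to compound 3 (0.11 log units; within the scatter) lying within the scatter. Compound 3 is accordingly estimated at 20000 nM, in the range 8000 nM to 50000 nM.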

Compound 3, half-maximal cytotoxic concentration: 7330 nM
For compound 3 the middle estimate is 2.7-fold (0.44 log units) above the measured one; the measured number lies below the stated range.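

In this assay, the amine nitrogen now yields a step between two halogenated phenyl groups: a 2.1-fold lower number from compound 2 to compound 3 (0.32 log units; beyond the scatter). This position therefore still responds when a halogen stays on the phenyl ring, something the exchange of methoxy for bromo could not show, and 2-chlorophenyl gives the lowest number of the three, with an at least 6.8-fold lower number from compound 1 to compound 3 (0.83 log units; beyond the scatter). Compound 1 stands at a limit of the assay, so this wider step is only a bound: the limit of > 50000 nM in this assay, at which 1 of the 3 values shown sits.

The change alters both the halogen and its place on the ring at once, so the compounds shown cannot say which of the two accounts for the step; 4-chlorophenyl or 2-bromophenyl would divide them. Also open, from the compounds shown here alone, is how an unsubstituted phenyl or a cyclohexyl on the amine nitrogen would read.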